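Swapping the sulfonyl aryl group: a clearance estimate

The compounds below may be only part of what the source reports. "The series", "measured", "known", "first", "only" and "open" are said of these compounds alone.

Compound 1 `O=S(=O)(c1ccc(F)c(F)c1)c1cnc2cc(F)ccc2c1-c1ccc(Cl)cc1`: 0.01 mL/min
Compound 2 `O=S(=O)(c1ccc(F)c(Cl)c1)c1cnc2cc(F)ccc2c1-c1ccc(Cl)cc1`: 0.39 mL/min
Compound 3 `O=S(=O)(c1ccc(F)cc1)c1cnc2cc(F)ccc2c1-c1ccc(Cl)cc1`: 1.23 mL/min

Three compounds sharing one core have been run in an ADME assay on microsomes from liver (Homo sapiens) for metabolic stability, tested at 2.5 uM; a higher number here means faster removal of the compound, a lower number slower removal. In this assay compound 3 gives 1.23 mL/min, the highest of the three numbers. Its nearest neighbour is compound 2, and the step of a 3.2-fold higher number from compound 2 to compound 3 (0.50 log units; beyond the scatter) is modest. The furthest is compound 1, and the step of a 120-fold higher number from compound 1 to compound 3 (2.09 log units; beyond the scatter) is large, as is the step of a 39-fold higher number from compound 1 to compound 2 (1.59 log units; beyond the scatter).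

Compound 4 `Cc1ccc(S(=O)(=O)c2cnc3cc(F)ccc3c2-c2ccc(Cl)cc2)cc1C` differs from compound 3 in one place: 3,4-dimethylphenyl in place of 4-fluorophenyl on a sulfonyl sulfur. All three measured steps alter a single atom on that same aromatic ring, and each removal or exchange of a halogen there pushed the number in this assay upward. Among the compounds with values here, none of them introduces a methyl group, so no measured step speaks directly to this change. Since every prior change on this ring moved the number in this assay higher, and compound 3 already stands highest, a small further rise is expected, with wide uncertainty.

Compound 4 is therefore estimated to give 2 mL/min in this assay, between 0.6 mL/min and 6 mL/min, an expected step of a 1.6-fold higher number from compound 3 to compound 4 (0.21 log units; within the scatter).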

Compound 4, intrinsic clearance in a liver preparation (reported as CLH), per the amount of preparation that the assay uses: 7.88 mL/min
Compound 4: middle estimate off by 3.9-fold (0.60 log units), on the low side; measured number above the stated range.
By their numbers in this assay, from the lowest: compound 1; then compound 2; then compound 3; then compound 4.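

Within the data shown here, the change to 3,4-dimethylphenyl on the sulfonyl sulfur gives a 6.4-fold higher number from compound 3 to compound 4 (0.81 log units; beyond the scatter) in this assay and shows that this position can raise the number through added methyl groups, whereas the earlier steps only exchanged a halogen or hydrogen on the ring. Against the halogen-bearing rings that share two substituted ring places with it, the steps are wider, with a 20-fold higher number from compound 2 to compound 4 (1.31 log units; beyond the scatter) and a 790-fold higher number from compound 1 to compound 4 (2.90 log units; beyond the scatter), so changing this one aryl group while the shared core stays fixed now covers a very broad range of clearance numbers, with 3,4-dimethylphenyl at the top and 3,4-difluorophenyl at the bottom. Nothing available explains why the methyl-bearing ring gives the highest number.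

The four compounds cannot show whether a single methyl group on this ring would raise the number as much as two do, since the methyl groups arrive together and with the loss of the fluorine. They also leave open how the number would respond to an amine, a carboxylic acid or a longer alkyl chain on this ring.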